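The source may report more compounds than this note shows. Statements on the series, on what has been measured and on what is new or still open speak of the compounds shown alone.

Measured so far:
Compound 1, `COc1ccc(NC(=O)Nc2cc(C)nc3ccccc23)cc1F`, gives > 25000 nM in an ADME assay on HEK293 cells (Homo sapiens) for cytotoxicity, with a stated time of 72 h (on this read-out higher numbers stand for an effect only at larger amounts of compound and lower numbers for an effect already at smaller amounts), a limit of the assay rather than a number.
Compound 2, `Cc1cc(NC(=O)Nc2ncccc2C)c2ccccc2n1`, gives > 25000 nM in this assay, again a limit.
Compound 3, `COc1cccc(NC(=O)Nc2cc(C)nc3ccccc23)c1`, gives > 25000 nM in this assay, also a limit.

Compound 2 therefore stands at the assay limit, and it shares this position with compound 1 and compound 3: the limit of > 25000 nM in this assay, at which 3 of the 3 values shown sit. For the measured compounds named here, no step between two measured compounds is available in this set, so nothing can be said about how far any single change has moved the read-out.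

Compound 4, `Cc1cc(NC(=O)Nc2cccnc2)c2ccccc2n1`, has not yet been measured. It differs from compound 2 in one place: pyridin-3-yl in place of 3-methylpyridin-2-yl on an amide-type nitrogen. The urea linkage and the shared core of compound 2 are kept.

With every measured value sitting at the limit, the expectation for compound 4 is that the step from compound 2 to compound 4 stays within the scatter, a step that the limit leaves unreadable from compound 2 to compound 4, and that the assay most likely again reports only a limit. The estimate for compound 4 in this assay is 40000 nM, with a range from 20000 nM to 100000 nM.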

Compound 4, half-maximal effective concentration: > 25000 nM
Compound 4 was reported as a limit; the forecaster's own chance of this, stated with the estimate: 85%; the middle value lies beyond the limit too.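

No step can be read from compound 2 to compound 4: both are reported in this assay only as limits, so pyridin-3-yl in place of 3-methylpyridin-2-yl has no readable size. The compounds shown leave open at what concentration any of them would show an effect, and whether any single change moves the read-out at all: the limit of > 25000 nM in this assay, at which 4 of the 4 values shown sit.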